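Swapping the Benzyl Group at an Unmeasurable Ceiling

The compounds below may be only part of what the source reports. "The series", "measured", "known", "first", "only" and "open" are said of these compounds alone.

Three compounds share one core and differ only in the aryl group on a saturated chain carbon bound to an aromatic nitrogen. Compound 1 `O=c1ccoc2cc(OCc3cn(Cc4cccc(Br)c4)nn3)ccc12` carries 3-bromophenyl there. In a functional assay on SGC-7901 cells (Homo sapiens) for cytotoxicity, read by MTT assay, with a stated time of 48 h (a lower number here means a stronger inhibitor, a higher number a weaker inhibitor), compound 1 gives only a limit of the assay, > 100000 nM. Compound 2 `O=c1ccoc2cc(OCc3cn(Cc4ccc(Cl)cc4Cl)nn3)ccc12` carries 2,4-dichlorophenyl. In this assay compound 2 likewise gives a limit, > 100000 nM. Compound 3 `COc1ccc(Cn2cc(COc3ccc4c(=O)ccoc4c3)nn2)cc1` carries 4-methoxyphenyl. In this assay compound 3 also returns a limit, > 100000 nM. Because every value rests at the limit of > 100000 nM in this assay, at which 3 of the 3 values shown sit, the steps between them cannot be sized: the change from compound 1 to compound 2 is a step that the two limits leave unreadable from compound 1 to compound 2, from compound 1 to compound 3 it is a step that the two limits leave unreadable from compound 1 to compound 3, and from compound 2 to compound 3 it is a step that the two limits leave unreadable from compound 2 to compound 3. Compound 2 therefore stands at the limit alongside the other two.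

Compound 4 `N#Cc1cccc(Cn2cc(COc3ccc4c(=O)ccoc4c3)nn2)c1` is the next member. Its change from compound 2 is 3-cyanophenyl in place of 2,4-dichlorophenyl on a saturated chain carbon bound to an aromatic nitrogen. Going by the values given here, no measured step is readable, so nothing among the three shows that any swap of this aryl group lifts the series into the measurable range; three such swaps left every value at the limit. The expected step from compound 2 to compound 4 is a step that the limit leaves unreadable from compound 2 to compound 4, most likely another limit. Compound 4 is expected to give about 150000 nM, within 40000 nM to 600000 nM.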

Compound 4, half-maximal inhibitory concentration: > 100000 nM
Compound 4: a limit, no number; the forecaster's own chance of this, stated with the estimate: 85%; the middle value does not contradict the limit.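

Compound 4 also returns only a limit, so no new step can be read from compound 4 to compound 1, compound 2 or compound 3, and all four compounds share one ceiling: the limit of > 100000 nM in this assay, at which 4 of the 4 values shown sit.

The compounds shown leave open whether any aryl group at this place gives a measurable value in this assay at all.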